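Swapping the aryl group at the saturated ring carbon

The source may hold more compounds than are shown below. What is called first, only, known or untested is meant among the compounds shown, and "the series" means these compounds.

Two compounds from this set share one core and differ only in the group on a saturated ring carbon. Compound 1 `N#CC1=C(N)N(c2ccc(S(N)(=O)=O)cc2)C2=C(CCCC2)C1c1ccc(O)cc1` carries a 4-hydroxyphenyl group there; in a functional assay on Ehrlich cells (Mus musculus) for cytotoxicity, read by trypan blue exclusion, with a stated time of 2 h, tested at 10 ug/mL (a higher number here means a stronger effect of the compound at the concentration tested, a lower number a weaker effect), compound 1 gives 20%. Compound 2 `N#CC1=C(N)N(c2ccc(S(N)(=O)=O)cc2)C2=C(CCCC2)C1c1ccc(Cl)c(Cl)c1` carries a 3,4-dichlorophenyl group instead, and in this assay compound 2 gives 1%. For the measured compounds named here, the one measured step, a number 19 percentage points lower from compound 1 to compound 2 (beyond the scatter), thus stands as a modest drop, beyond the scatter. Going by the values given here, on these two numbers compound 2 stands lowest, with compound 1 as its only neighbour, and the gap between them lies beyond the scatter.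

Compound 3 `Cc1ccc(C2C(C#N)=C(N)N(c3ccc(S(N)(=O)=O)cc3)C3=C2CCCC3)o1` has not yet been measured. The change from compound 2 is 5-methylfuran-2-yl in place of 3,4-dichlorophenyl on a saturated ring carbon. Among the compounds with values here, the only measured step at this position, a number 19 percentage points lower from compound 1 to compound 2 (beyond the scatter), shows that the group on this carbon can move the read-out beyond the scatter, but no measured pair exchanges an aryl ring for a five-membered aromatic ring with one hetero atom, so the direction is open. Compound 2 sits at the floor of the read-out, so a step down cannot be seen. Compound 3 is therefore expected to give 8%, between 0% and 25%, a step of a number 7 percentage points higher from compound 2 to compound 3 (within the scatter) that is estimated to stay close to the scatter.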

Compound 3, a percentage reported as activity, at one concentration (the size of the read-out at that concentration, not a potency): 0%
Compound 3: middle estimate off by 8 percentage points, on the high side; low and high end bracket the measured number.
By their numbers in this assay, from the lowest: compounds 3 and 2 (each within the scatter of the next); then compound 1.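

In this assay, exchanging the six-membered aromatic ring of carbon only for a five-membered aromatic ring with one hetero atom leaves the read-out within the scatter (a number 1 percentage points lower from compound 2 to compound 3 (within the scatter)), so on this saturated ring carbon 5-methylfuran-2-yl and 3,4-dichlorophenyl cannot be told apart. The comparison with the 4-hydroxyphenyl group now rests on two replacements instead of one, and the second gives a drop beyond the scatter of modest size (a number 20 percentage points lower from compound 1 to compound 3 (beyond the scatter)), so among these three compounds compound 1 alone stands apart, while compound 2 and compound 3 both lie near the floor of the read-out, where any further loss could not be seen. Nothing available here accounts for the separation of compound 1 from the other two.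

The compounds shown leave open whether the hydroxyl group itself sets compound 1 apart, since a plain phenyl, a 4-methoxyphenyl or a 4-aminophenyl group on the same carbon would be needed to test that. They also leave open how a saturated group such as cyclohexyl, or a furan without its methyl group, would read at this position.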